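The source may report more compounds than this note shows. Statements on the series, on what has been measured and on what is new or still open speak of the compounds shown alone.

Measured to date in an assay on HL-60 cells for inhibition of glutathione S-transferase P (Homo sapiens), read by spectrophotometry, tested at 20 uM; a higher number here means more inhibition at the concentration tested (going by the name of the read-out), a lower number less inhibition:
- compound 1, `COc1ccccc1/C=C1\CN(CC(=O)O)c2c(C)cccc2C1=O`: 4.72%
- compound 2, `CCOc1ccccc1/C=C1\CN(CC(=O)O)c2c(C)cccc2C1=O`: 15.4%
- compound 3, `COc1ccc(/C=C2\CN(CC(=O)O)c3ccc(C)cc3C2=O)cc1`: 17.5%

Within the core of compound 1, the change methyl in place of hydrogen on a saturated chain carbon bound to an oxygen on an aromatic ring gives a number 10.7 percentage points higher from compound 1 to compound 2 (beyond the scatter). Compound 3 carries a different core; the difference between the two cores is not broken down here. Against compound 1 compound 3 reads higher, whereas its value and that of compound 2 lie within the scatter of each other.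

Compound 4, `CCOc1ccc(/C=C2\CN(CC(=O)O)c3ccc(C)cc3C2=O)cc1`, is not yet measured. It relates to compound 3 by methyl in place of hydrogen on a saturated chain carbon bound to an oxygen on an aromatic ring, the same change as from compound 1 to compound 2, at a place described in the same words. Among the compounds with values here, the earlier step is the only guide, so a step of similar direction but uncertain size is expected: for compound 4 the estimate is a number 7.5 percentage points higher from compound 3 to compound 4 (within the scatter). Compound 4 is thus expected to give 25%, between 13% and 37%.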

Compound 4, a percentage reported as inhibition, at one concentration (the size of the read-out at that concentration, not a potency): 25.8%
Compound 4: middle estimate off by 0.8 percentage points, on the low side, within the range that was stated.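

Going from methoxy to ethoxy on the core of compound 3 gives a number 8.3 percentage points higher from compound 3 to compound 4 (within the scatter) in this assay. The same change thus reads alike on the two cores, with no difference between the steps that can be told apart: the same change on two cores in this assay, a number 10.7 percentage points higher (beyond the scatter) from compound 1 to compound 2 and a number 8.3 percentage points higher (within the scatter) from compound 3 to compound 4, 2.4 percentage points apart, within the scatter of two such steps

This rests on two pairs only, one of them a step within the scatter, and on readings at a single concentration rather than potencies, so it shows no rule for other cores and fixes no exact size for the step.

Open, from the compounds shown here alone, is whether a propoxy group or a longer chain would continue the step. Also open, going by these compounds, is what an amine in place of the ether oxygen would give.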